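Swapping an Isopropyl for a Longer Alkyne Ketone Chain

The compounds below may be only part of what the source reports. "The series", "measured", "known", "first", "only" and "open" are said of these compounds alone.

Three compounds built on a shared core were tested in a functional assay on HT-29 cells (Homo sapiens) for antiproliferative activity, read by CellTiter-Glo, with a stated time of 72 h; a higher number here means a weaker inhibitor, a lower number a stronger inhibitor. Compound 1, `Cc1cc(C)c(S(=O)(=O)N2CCC(N3CCC(C(C)C)CC3)CC2)c(C)c1`, gives 0.2 nM, the lowest of the three numbers. Compound 2, `CC1CCN(C2CCN(S(=O)(=O)c3cccc4ccccc34)CC2)CC1`, gives 0.34 nM, which lies within the scatter of the value of compound 1. Compound 3, `Cc1cc(S(=O)(=O)N2CCC(N3CCC(C)CC3)CC2)c(Cl)cc1Cl`, gives 1.1 nM, and its gap from compound 1 goes beyond the scatter. No two of these compounds differ in only one place, so no single measured step can be read from them.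

Compound 4, `C#CCCC(=O)CC1CCN(C2CCN(S(=O)(=O)c3c(C)cc(C)cc3C)CC2)CC1`, differs from compound 1 in one place: ((but-3-yn-1-yl)carbonyl)methyl in place of isopropyl on a saturated ring carbon. The incoming group brings more heavy atoms than the isopropyl it replaces, together with a carbonyl and a triple bond. Going by the values given here, none of the measured compounds carries a group of this kind on that saturated ring carbon, so there is no measured step to lean on, and the expectation rests on the size of the change alone. A modest weakening is expected from it. Compound 4 is therefore expected to give 0.6 nM, within a range from 0.15 nM to 2.5 nM. The expected step of a 3.0-fold higher number from compound 1 to compound 4 (0.48 log units; beyond the scatter) is a loss that would count beyond the scatter, though smaller than the gap between compound 1 and compound 3.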

Compound 4, half-maximal inhibitory concentration: 2.1 nM
Estimate against measurement, compound 4: 3.5-fold (0.54 log units) below, and the stated range covers the measured number.
By their numbers in this assay, from the lowest: compounds 1 and 2 (each within the scatter of the next); then compounds 3 and 4 (each within the scatter of the next).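

In this assay, going by these compounds alone, ((but-3-yn-1-yl)carbonyl)methyl in place of isopropyl on this saturated ring carbon gives an 11-fold higher number from compound 1 to compound 4 (1.02 log units; beyond the scatter), a large loss that offers the first direct reading of a change at this position. Within the data shown here, compound 4 still gives 2.1 nM, so this position can carry the longer chain with its carbonyl and triple bond while activity remains measurable, but at a clear cost relative to isopropyl; compound 2 and compound 3 differ from compound 4 in more than one place, so no steps to them can be read. Nothing measured here bears on why this step is so large.

The incoming group brings greater chain length, a carbonyl and a triple bond together, so the compounds shown leave open which of these features accounts for the loss. A plain hexyl chain, or a shorter chain ending in an amine or a carboxylic acid on the same ring carbon, would help separate these features.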